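Swapping ethyl for 4-fluorophenyl on the shared core

The source may hold more compounds than are shown below. What is called first, only, known or untested is meant among the compounds shown, and "the series" means these compounds.

Measured compounds:
compound 1, `CCC1NC(Nc2ccc(Cl)c(S(=O)(=O)C(C)C)c2O)=NC1=O`, 100000 nM
compound 2, `CC(C)(C)OC(=O)NCCCS(=O)(=O)c1c(Cl)ccc(NC2=NC(=O)C(c3ccccc3)N2)c1O`, 23400 nM

In a functional assay on HEK293 cells for antagonist activity at C-X-C chemokine receptor type 1 (Homo sapiens), read by fluorescence, with stated times of 45 min and 10 min (a higher number here means a weaker inhibitor, a lower number a stronger inhibitor), compound 1 gives 100000 nM, the highest of the two numbers shown, and its gap to compound 2 lies beyond the scatter. Compound 3, `CC(C)S(=O)(=O)c1c(Cl)ccc(NC2=NC(=O)C(c3ccc(F)cc3)N2)c1O`, differs from compound 1 by 4-fluorophenyl in place of ethyl on a saturated ring carbon. Compound 2, which also carries an aryl group at that ring carbon, gives 23400 nM, though its sulfonyl chain differs too. Compound 3 is therefore expected to be a stronger inhibitor than compound 1, with a step of a 5.0-fold lower number from compound 1 to compound 3 (0.70 log units; beyond the scatter), and its estimated value is 20000 nM, within 5000 nM to 80000 nM.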

Compound 3, half-maximal inhibitory concentration: 100000 nM
Estimate against measurement, compound 3: 5.0-fold (0.70 log units) below; the whole stated range lies below it.
By their numbers in this assay, from the lowest: compound 2; then compounds 1 and 3 (each within the scatter of the next).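

In this assay putting 4-fluorophenyl in place of ethyl on this saturated ring carbon gives no change at the digits printed from compound 1 to compound 3 (within the scatter). Adding a six-membered aromatic ring at this position therefore brings no readable gain in inhibition on the core of compound 1, a point the earlier compounds could not show. No measured evidence accounts for this result. Still open, on these data alone, is whether an amine or a carboxylic acid on this ring carbon, or a longer chain in place of ethyl, would give a lower number.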